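Swapping 4-methoxyphenyl for 3-cyanophenyl

This account rests on a few compounds, and the source may have more. Where it says the series, first, only, none or still open, it means among the compounds named here.

In a functional assay on MCF7 cells (Homo sapiens) for inhibition, read by MTT assay, with a stated time of 72 h, tested at 50 uM (a lower number here means less inhibition of growth, a higher number more inhibition of growth at the concentration tested), compound 3 (`C#CCOc1ccc(CC=C)cc1O`) gives 15.8% and compound 1 (`C=CCc1ccc(OCc2cn(-c3ccccc3Cl)nn2)c(O)c1`) gives 34.3% while compound 2 (`C=CCc1ccc(OCc2cn(-c3ccc(OC)cc3)nn2)c(O)c1`) gives 57.2% as the highest of the three. Compound 4 (`C=CCc1ccc(OCc2cn(-c3cccc(C#N)c3)nn2)c(O)c1`) differs from compound 2 at one place, with 3-cyanophenyl in place of 4-methoxyphenyl on an aromatic nitrogen. Among the measured compounds shown here, only one measured step involves this same place. Putting 4-methoxyphenyl in place of 2-chlorophenyl gave a number 22.9 percentage points higher from compound 1 to compound 2 (beyond the scatter) in this small set, so a change here can move the reading. Neither of those two compounds carries a nitrile, which means that step suggests a size but not a direction. With compound 2 already the highest at 57.2% among three compounds, a fall seems likelier than a rise. The expected step is a fall of similar or smaller size, estimated as a number 14.2 percentage points lower from compound 2 to compound 4 (beyond the scatter) in this assay for the new group. Compound 4 is estimated at 43% with a likely range from 26% to 60% in this assay once tested.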

Compound 4, percent growth inhibition at one concentration: 33.4%
Beside the measured number, compound 4's estimate is 9.6 percentage points above it; the range from low to high includes it.
By their numbers in this assay, from the lowest: compound 3; then compounds 4 and 1 (each within the scatter of the next); then compound 2.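

Under this assay the swap to 3-cyanophenyl gives a number 23.8 percentage points lower from compound 2 to compound 4 (beyond the scatter) and so shows that a change at this place on the aromatic nitrogen can lower the reading as well as raise it. Among the compounds shown here, the swap from 2-chlorophenyl to 3-cyanophenyl gives a number 0.9 percentage points lower from compound 1 to compound 4 (within the scatter) and so these two different groups read alike, which leaves 4-methoxyphenyl as the one group of the three that stands apart. No measurement shown here accounts for the gap between these groups.

From the compounds shown here alone, it remains open whether 4-methoxyphenyl stands apart for its methoxy group or simply as one case among few. A plain phenyl, or a phenyl carrying an amine or a carboxylic acid, could show whether other groups here read closer to compound 2 or to compound 4.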